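Working notes: benzyl for phenyl on compound 1

The source may hold more compounds than are shown below. What is called first, only, known or untested is meant among the compounds shown, and "the series" means these compounds.

Measured so far:
- compound 1 `COc1cc(/C=N/c2c(C#N)ncn2-c2ccc(F)cc2)cc(OC)c1OC`: 18700 nM
- compound 2 `COc1ccc(/C=N/c2c(C#N)ncn2-c2ccc(F)cc2)cc1OC`: 4270 nM

In a functional assay on MDA-MB-231 cells (Homo sapiens) for antiproliferative activity, read by MTT assay, with a stated time of 48 h (on this read-out lower numbers stand for stronger inhibition and higher numbers for weaker inhibition), compound 1 gives the higher of the two numbers; compound 2, which differs by hydrogen in place of methoxy on an aromatic carbon, gives 4270 nM, a step of a 4.4-fold lower number from compound 1 to compound 2 (0.64 log units; beyond the scatter).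

Compound 3 `COc1cc(/C=N/c2c(C#N)ncn2Cc2ccc(F)cc2)cc(OC)c1OC` is not yet measured. It differs from compound 1 by 4-fluorobenzyl in place of 4-fluorophenyl on an aromatic nitrogen. Among the compounds with values here, no measured step touches this position: the single step from compound 1 to compound 2 changes a methoxy on the other aromatic ring and says nothing about the group on the aromatic nitrogen. There is therefore no basis for a directed expectation in this assay, and a step no larger than the scatter is the default, with a wide range to either side.

Compound 3 is expected to give about 17000 nM in this assay, between 5000 nM and 60000 nM, which as a step from compound 1 means a 1.1-fold lower number from compound 1 to compound 3 (0.04 log units; within the scatter).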

Compound 3, half-maximal inhibitory concentration: 2870 nM
Compound 3: middle estimate off by 5.9-fold (0.77 log units), on the high side, and the stated range ends above it.
By their numbers in this assay, from the lowest: compounds 3 and 2 (each within the scatter of the next); then compound 1.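

In this assay, the group on the aromatic nitrogen proves to be a sensitive point on the core of compound 1: 4-fluorobenzyl in place of 4-fluorophenyl gives a 6.5-fold lower number from compound 1 to compound 3 (0.81 log units; beyond the scatter). Within the data shown here, the earlier step changed only a methoxy on the other aromatic ring, so this is the first reading at this position, and it shows that the group on the aromatic nitrogen can shift the number beyond the scatter. No available evidence bears on the reason for this step.

Going by these compounds, whether the same change carries over to the methoxy pattern of compound 2 remains open. Also open, on these data alone, is how the position responds to an unsubstituted benzyl, a longer chain such as 2-phenylethyl, or a chain ending in an amine.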